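Removing One Chloro Group From a Dichlorophenyl Ether

A few compounds are considered here, and "the series" means these few. Any claim that something is new, unique, unknown or untested is made for them only; others in the source may bear on it.

Of the compounds shown here, two of a shared core have been tested for antiproliferative activity. Compound 1 `NC1=NC2(CCSCC2)N(OCCCOc2cccc(Cl)c2)C(N)=N1` carries a 3-chlorophenyl group, and in a functional assay on MDA-MB-231 cells (Homo sapiens) for antiproliferative activity, read by MTT assay, with a stated time of 72 h (a higher number here means a weaker inhibitor, a lower number a stronger inhibitor), compound 1 gives 130 nM. Compound 2 `NC1=NC2(CCOCC2)N(OCCCOc2cccc(Cl)c2Cl)C(N)=N1` carries a 2,3-dichlorophenyl group and a different ring in its core, and in this assay compound 2 gives 140 nM. Of the two numbers, that of compound 2 is the highest, but the nearest is compound 1 and the two lie within the scatter of each other, so neither can be called the stronger. Compound 1 and compound 2 differ in two places, so their gap cannot be assigned to either change alone.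

Compound 3 `NC1=NC2(CCOCC2)N(OCCCOc2cccc(Cl)c2)C(N)=N1` shares the core of compound 2 and differs from it in one place: hydrogen in place of chloro on an aromatic carbon. Within the data shown here, no step between measured compounds exists to anchor this change. Compound 1 with its 3-chlorophenyl gives 130 nM and compound 2 with its 2,3-dichlorophenyl gives 140 nM, values within the scatter of each other, and on that showing no movement beyond the scatter is expected. The expected step is a 1.1-fold higher number from compound 2 to compound 3 (0.03 log units; within the scatter). Compound 3 is estimated at 150 nM in this assay, with a range from 70 nM to 320 nM.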

Compound 3, half-maximal inhibitory concentration: 1020 nM
Compound 3: the middle estimate sits 6.8-fold (0.83 log units) below what was measured; measured number outside the range, above it.
By their numbers in this assay, from the lowest: compounds 1 and 2 (each within the scatter of the next); then compound 3.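

In this assay, the change from 2,3-dichlorophenyl to 3-chlorophenyl on the shared core gives a 7.3-fold higher number from compound 2 to compound 3 (0.86 log units; beyond the scatter), so the chloro group on this aromatic carbon, ortho to a chloro group and ortho to a large group, matters for the number on this core. The earlier pair could not show this, and the new value also shows that the 3-chlorophenyl group does not set the number by itself: the core of compound 1, which carries that group too, differs in one place from that of compound 3. Compound 3 gives 1020 nM, while compound 1 gives 130 nM. Nothing in the available data explains why the loss of this one chlorine goes with so large a step.

The compounds shown leave open whether chloro is particular in this place, or whether a fluoro, a methyl or a methoxy group on the same aromatic carbon would hold the number near that of compound 2. They also leave open whether the same step would appear on the core of compound 1, where a 2,3-dichlorophenyl partner for that compound does not stand among those shown.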